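Trifluoromethyl in Place of Sulfamoyl: an Expected Step

The source may hold more compounds than are shown below. What is called first, only, known or untested is meant among the compounds shown, and "the series" means these compounds.

Compound 1 `N#CC1CN1C(=O)Nc1ccc(S(N)(=O)=O)cc1`: in a functional assay on L1210 cells (Mus musculus) for inhibition, read by MTT assay (a higher number here means a weaker inhibitor, a lower number a stronger inhibitor), compound 1 gives > 38000 nM, which is a limit of the assay and not a number.
Compound 2 `CC(C)(C)NC(=O)N1CC1C#N`: in this assay compound 2 gives 457000 nM.

Compound 1 therefore stands only at the limit of > 38000 nM in this assay, at which 1 of the 2 values shown sits, and its true value is not pinned down. Compound 2 is a different molecule with no single-point link to compound 1, so its value is simply what it shows. Compound 3 `N#CC1CN1C(=O)Nc1ccc(C(F)(F)F)cc1` is the untested partner of compound 1, and the change is trifluoromethyl in place of sulfamoyl on an aromatic carbon. Among the compounds with values here, no measured pair in this set covers such a change, so there is no step size to lean on. The step from compound 1 to compound 3 is expected to be a step that the limit leaves unreadable from compound 1 to compound 3, that is, no change beyond the usual scatter in either direction. Compound 3 is thus expected to give about 60000 nM in this assay, with a likely range from 15000 nM to 300000 nM.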

Compound 3, half-maximal inhibitory concentration: 7100 nM
Beside the measured number, compound 3's estimate is 8.5-fold (0.93 log units) above it, outside the stated range (below it).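

Trifluoromethyl in place of sulfamoyl gives the first readable sign that the group on this aromatic carbon matters: in this assay the change gives an at least 5.3-fold lower number from compound 1 to compound 3 (0.72 log units; beyond the scatter), which means a stronger inhibitor. For compound 1, > 38000 nM is a limit of the assay and not a number. The step is therefore a minimum, and its true size stays unknown: the limit of > 38000 nM in this assay, at which 1 of the 3 values shown sits.

This single pair cannot say whether the difference comes from gaining trifluoromethyl or from losing sulfamoyl, as the two groups differ in their atoms and in their hydrogen-bond donors and acceptors. As far as these compounds go, how a chlorine atom, a methoxy group or an amine on the same aromatic carbon would read in this assay also stays open.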